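Working notes: from 3-bromophenyl to 4-bromophenyl

The source may report more compounds than this note shows. Statements on the series, on what has been measured and on what is new or still open speak of the compounds shown alone.

- compound 1 `COc1cc(C(=O)c2cn(-c3ccccc3)cc2-c2ccc(Cl)cc2)cc(OC)c1OC`: 290 nM
- compound 2 `COc1cc(C(=O)c2cn(-c3ccccc3)cc2-c2cccc(Br)c2)cc(OC)c1OC`: 950 nM

Both values come from a functional assay on MCF7 cells (Homo sapiens) for cytotoxicity, read by MTT assay, with a stated time of 96 h; on this read-out higher numbers stand for weaker inhibition and lower numbers for stronger inhibition. Of the two, compound 2 has the higher number and so shows the weaker inhibition. The next compound, compound 3 `COc1cc(C(=O)c2cn(-c3ccccc3)cc2-c2ccc(Br)cc2)cc(OC)c1OC`, has 4-bromophenyl in place of the 3-bromophenyl of compound 2 on an aromatic carbon, with the rest of the structure unchanged: 4-bromophenyl in place of 3-bromophenyl on an aromatic carbon.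

Among the measured compounds shown here, only one measured step bears on this change: a 3.3-fold higher number from compound 1 to compound 2 (0.52 log units; beyond the scatter), beyond the scatter. That step replaces 4-chlorophenyl with 3-bromophenyl, so it changes the halogen and its place together, and the data do not separate the two. Compound 3 carries 4-bromophenyl where compound 1 carries 4-chlorophenyl, so the expectation rests on compound 1 at 290 nM. A modest step toward a lower number is therefore expected in this assay, opposite in direction to the measured one and of similar size. The estimated step is a 3.0-fold lower number from compound 2 to compound 3 (0.47 log units; beyond the scatter). For compound 3 the expected value is 320 nM, with an estimated range of 120 nM to 850 nM.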

Compound 3, half-maximal inhibitory concentration: 340 nM
Compound 3: middle estimate off by 1.1-fold (0.03 log units), on the low side; the measured number falls inside the stated range.
By their numbers in this assay, from the lowest: compounds 1 and 3 (each within the scatter of the next); then compound 2.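

In this assay, shifting the bromine around the phenyl ring gives a 2.8-fold lower number from compound 2 to compound 3 (0.45 log units; beyond the scatter) with the halogen held constant, so the place of the bromine on the phenyl ring alone moves the number, a point the earlier step could not separate from the change of halogen. Bromo in place of chloro gives a 1.2-fold higher number from compound 1 to compound 3 (0.07 log units; within the scatter) and so leaves compound 1 and compound 3 within the scatter of each other, which means that among these three compounds the gap in a 3.3-fold higher number from compound 1 to compound 2 (0.52 log units; beyond the scatter) goes with the move to 3-bromophenyl and not with the halogen itself. No measurement in hand explains why the 3-bromophenyl compound stands apart from the two 4-halophenyl compounds.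

Among the compounds shown here, whether the same gap between the 3-substituted and 4-substituted rings holds for other groups remains open, since bromine supplies the only such pair here; a 3-chlorophenyl or 4-methoxyphenyl ring would test this directly. Also open, on these data alone, is how an aminophenyl or carboxyphenyl ring at this carbon would compare with the halophenyl rings, and whether the order of these three compounds carries over to other cell lines.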